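The source may hold more compounds than are shown below. What is called first, only, known or untested is meant among the compounds shown, and "the series" means these compounds.

Working notes on the fluorophenyl naphthalene series in an assay for inhibition of steroid 17-alpha-hydroxylase/17,20 lyase (Homo sapiens), tested at 2 uM; a lower number here means a weaker effect, a higher number a stronger effect of the compound at the concentration tested.

Of the compounds shown here, three have numbers so far. Compound 1 `Fc1ccc(-c2ccc3c(-c4cccnc4)cccc3c2)cc1` gives 3%. Compound 2 `Fc1ccc(-c2ccc3c(-c4ccncc4)cccc3c2)cc1` gives 28%. Compound 3 `Fc1ccc(-c2ccc3cc(-c4cccnc4)ccc3c2)cc1` gives 22%. Within the data shown here, the only single-point step among them is a number 25 percentage points higher from compound 1 to compound 2 (beyond the scatter). Compound 2 gives the highest of the three numbers, but compound 3 lies within the scatter of it, so the two cannot be ranked; only compound 1 sits clearly lower.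

The next compound, compound 4 `Fc1ccc(-c2ccc3c(Cn4ccnc4)cccc3c2)cc1`, departs from compound 2 by (1H-imidazol-1-yl)methyl in place of pyridin-4-yl on an aromatic carbon.

Among the measured compounds shown here, no measured step bears directly on this change: the one step known, from compound 1 to compound 2, moves the nitrogen within a six-membered ring and was modest, whereas here a six-membered ring with one hetero atom gives way to a five-membered ring with two hetero atoms joined through a methyl. The step is therefore unsupported by any analogue, and the expectation can only be wide. On that basis a small decrease, a number 6 percentage points lower from compound 2 to compound 4 (within the scatter), is expected for compound 4, with a range that spans both a clear loss and a modest gain. Compound 4 is estimated at 22%, between 3% and 60%.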

Compound 4, a percentage reported as inhibition, at one concentration (the size of the read-out at that concentration, not a potency): 19%
Beside the measured number, compound 4's estimate is 3 percentage points above it; low and high end bracket the measured number.
By their numbers in this assay, from the lowest: compound 1; then compounds 4, 3 and 2 (each within the scatter of the next).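

At this aromatic carbon in this assay, (1H-imidazol-1-yl)methyl in place of pyridin-4-yl gives a number 9 percentage points lower from compound 2 to compound 4 (within the scatter), so a five-membered aromatic ring with 2 hetero atoms, carried on a methyl, cannot be told apart from the six-membered aromatic ring of compound 2. The same group in place of pyridin-3-yl gives a number 16 percentage points higher from compound 1 to compound 4 (beyond the scatter), which shows that the clear gap at this position is not confined to the two pyridine isomers: among the three groups compared here, only pyridin-3-yl stands clearly apart from the other two. No measurement at hand accounts for either step, and the numbers alone cannot say what separates pyridin-3-yl from the other groups.

Still open, as far as these compounds go, is how the (1H-imidazol-1-yl)methyl group would read on the attachment point that carries pyridin-3-yl in compound 3, and whether a 2-(1H-imidazol-1-yl)ethyl chain or a directly attached imidazol-1-yl ring would hold the read-out at this position. Since each number comes from a single concentration, the compounds shown also leave open whether compound 2 and compound 4 would show a stronger or weaker effect at any other concentration.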